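This account rests on a few compounds, and the source may have more. Where it says the series, first, only, none or still open, it means among the compounds named here.

Measured in an ADME assay on BCBL1 cells (Homo sapiens) for cytotoxicity, with a stated time of 7 days; a higher number here means that more compound is tolerated, a lower number that less compound is tolerated:
- compound 1 `CNc1nc(N)nc2c1ncn2/C=C1/CC1(CO)CO` gives 67000 nM
- compound 2 `CCCSc1nc(N)nc2c1ncn2/C=C1/CC1(CO)CO` gives > 20000 nM (a limit, not a number)
- compound 3 `Nc1nc(NC2CCCC2)c2ncn(/C=C3/CC3(CO)CO)c2n1` gives 71700 nM

Only compound 1 and compound 3 carry numbers in this assay, and the two cannot be told apart: a 1.1-fold higher number from compound 1 to compound 3 (0.03 log units; within the scatter). Compound 3 therefore stands level with compound 1 within the scatter. The other value in the set is the limit of > 20000 nM in this assay, at which 1 of the 3 values shown sits, and it gives no rank. The steps a step that the limit leaves unreadable from compound 1 to compound 2 and a step that the limit leaves unreadable from compound 2 to compound 3 add nothing to the estimate.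

The next compound is compound 4 `Nc1nc(NC2CCCCC2)c2ncn(/C=C3/CC3(CO)CO)c2n1`, which has cyclohexyl in place of cyclopentyl on a nitrogen on an aromatic ring. The same difference, cut one bond further out, reads cyclopentylamino to cyclohexylamino.

For the measured compounds named here, only one readable step changes the group on this nitrogen, cyclopentyl in place of methyl in compound 3, and it stayed within the scatter: a 1.1-fold higher number from compound 1 to compound 3 (0.03 log units; within the scatter). No shift beyond the scatter is expected in either direction, on this single step. The expected step is a 1.1-fold lower number from compound 3 to compound 4 (0.04 log units; within the scatter). For compound 4 the estimated value is 65000 nM, with an expected range from 30000 nM to 120000 nM.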

Compound 4, half-maximal cytotoxic concentration: > 20000 nM
Compound 4: a limit, no number (the forecaster's own chance of this, stated with the estimate: 30%); the middle value does not contradict the limit.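

In this assay, for the compounds shown here, compound 4 gives > 20000 nM, a limit and not a number, so no step linking compound 4 to compound 1, compound 2 or compound 3 can be read. Still open, as far as these compounds go, is whether cyclohexyl in place of cyclopentyl on this nitrogen changes the tolerated concentration at all, and where compound 2 and compound 4 rank.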